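This account rests on a few compounds, and the source may have more. Where it says the series, first, only, none or still open, it means among the compounds named here.

Compound 1 `COc1ccc(C[C@@H](O)/C=C/C=C/C(=O)NCc2ccc(Cl)cc2)cc1OC` measured at 13400 nM 
Compound 2 `COc1ccc(C[C@@H](O)/C=C/C=C/C(=O)NCc2ccccc2)cc1OC` measured at 12900 nM 

In a functional assay on HeLa cells (Homo sapiens) for antiproliferative activity, read by sulforhodamine B assay, with a stated time of 48 h (a higher number here means a weaker inhibitor, a lower number a stronger inhibitor), compound 2 at 12900 nM stands within the scatter of compound 1 at 13400 nM on the two numbers available. Compound 3 `COc1ccc(CNC(=O)/C=C/C=C/[C@H](O)Cc2ccc(OC)c(OC)c2)cc1` differs from compound 2 by methoxy in place of hydrogen on an aromatic carbon in a single place, with methoxy in place of hydrogen on an aromatic carbon. Within the data shown here, no measured compound carries the 4-methoxybenzyl group, so the evidence is thin. Among the measured compounds shown here, the one measured step that bears on this change is a 1.0-fold lower number from compound 1 to compound 2 (0.02 log units; within the scatter) for hydrogen in place of chloro on an aromatic carbon. That step alone offers no reason to expect movement in either direction in this assay for the new group. The expected change is a 1.0-fold higher number from compound 2 to compound 3 (0.00 log units; within the scatter) and thus nothing beyond the scatter. Compound 3 is estimated at 13000 nM with 6500 nM to 26000 nM as its expected range.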

Compound 3, half-maximal inhibitory concentration: 9450 nM
Compound 3: the middle estimate sits 1.4-fold (0.14 log units) above what was measured; the measured number falls inside the stated range.
By their numbers in this assay, from the lowest: compounds 3, 2 and 1 (each within the scatter of the next).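

In this assay, methoxy in place of hydrogen on this aromatic carbon gives a 1.4-fold lower number from compound 2 to compound 3 (0.14 log units; within the scatter), and methoxy in place of chloro at the same place gives a 1.4-fold lower number from compound 1 to compound 3 (0.15 log units; within the scatter). Among these compounds, the position para to a large group has now carried hydrogen, chloro and methoxy, and no step among compounds 1, 2 and 3 leaves the scatter, so the 4-methoxybenzyl group adds a third case to the same flat reading. Nothing at hand offers an explanation for how close these numbers lie.

Still open, as far as these compounds go, is whether an amine, a carboxylic acid or a longer chain such as butoxy at this place would move the number beyond the scatter. The compounds shown also leave open whether a methoxy on another carbon of the same ring would behave as this one does.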